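A few compounds are considered here, and "the series" means these few. Any claim that something is new, unique, unknown or untested is made for them only; others in the source may bear on it.

Numbers in an assay on isolated protein for displacement of a labelled ligand from metabotropic glutamate receptor 5 (Homo sapiens), with a stated time of 60 min, tested at 1 uM; a higher number here means more inhibition at the concentration tested (going by the name of the read-out), a lower number less inhibition:
compound 1 `CC1CCN(c2c(S(=O)(=O)c3cccc(F)c3)cnc3ccc(F)cc23)CC1`, 76%
compound 2 `CC1CCN(c2c(S(=O)(=O)c3ccccc3)cnc3ccc(F)cc23)CC1`, 40%
compound 3 `Cc1ccc2ncc(S(=O)(=O)c3ccccc3)c(N3CCC(C)CC3)c2c1`, 67%

Compound 2 stands lowest of the three; compound 3 lies a number 27 percentage points higher from compound 2 to compound 3 (beyond the scatter), and the drop a number 36 percentage points lower from compound 1 to compound 2 (beyond the scatter) separates compound 1 from compound 2, both beyond the scatter. Compound 4 `CC1CCN(c2c(S(=O)(=O)c3cccc(C#N)c3)cnc3ccc(F)cc23)CC1` differs from compound 2 by cyano in place of hydrogen on an aromatic carbon. The step that bears directly on this is a number 36 percentage points lower from compound 1 to compound 2 (beyond the scatter), where a fluoro at the same place on the same ring was lost; the step of a number 27 percentage points higher from compound 2 to compound 3 (beyond the scatter) concerns the shared core and bears less. Putting a group back at that place is therefore expected to raise the number in this assay, by a step comparable in size. For compound 4 the estimate is 66%, range 45% to 85%. That estimate means a step of a number 26 percentage points higher from compound 2 to compound 4 (beyond the scatter), expected beyond the scatter.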

Compound 4, a percentage reported as inhibition, at one concentration (the size of the read-out at that concentration, not a potency): 93%
Compound 4: the middle estimate sits 27 percentage points below what was measured, outside the stated range (above it).
By their numbers in this assay, from the lowest: compound 2; then compounds 3 and 1 (each within the scatter of the next); then compound 4.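

In this assay phenyl to 3-cyanophenyl gives a number 53 percentage points higher from compound 2 to compound 4 (beyond the scatter) at this position, so the gain over hydrogen is not confined to fluoro. The nitrile also separates from fluoro at the same place, with a number 17 percentage points higher from compound 1 to compound 4 (beyond the scatter) in the same assay. Nothing measured here accounts for this gain.

Going by these compounds, whether other groups at this position, such as an amine, a carboxylic acid or a methoxy group, hold or extend the gain remains open. Also open, on these data alone, is whether the cyano change carries over to the methyl-bearing core of compound 3.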